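The source may report more compounds than this note shows. Statements on the series, on what has been measured and on what is new or still open speak of the compounds shown alone.

Measured compounds in a functional assay on A549 cells (Homo sapiens) for antiproliferative activity, read by sulforhodamine B assay, with a stated time of 48 h; a higher number here means a weaker inhibitor, a lower number a stronger inhibitor:
compound 1 `COc1ccc2nc(-c3ccc(N/C=C\C(=O)c4ccc(OC)c(O)c4)cc3)sc2c1`: 12800 nM
compound 2 `COc1ccc2nc(-c3ccc(N/C=C\C(=O)c4cc(OC)c(OC)c([N+](=O)[O-])c4)c(C)c3)sc2c1`: 22100 nM
compound 3 `COc1ccc2nc(-c3ccc(N/C=C\C(=O)c4cc(OC)c(OC)c(OC)c4Br)c(C)c3)sc2c1`: 6400 nM

Compound 3 shows the lowest of the three numbers in this assay. Its gap to compound 1 lies within the scatter, so no order between those two is claimed, while its gap to compound 2 lies beyond the scatter. The unmeasured compound 4 `COc1ccc2nc(-c3ccc(N/C=C\C(=O)c4cc(OC)c(OC)c(OC)c4)c(C)c3)sc2c1` differs from compound 3 in one place: hydrogen in place of bromo on an aromatic carbon. Among the compounds with values here, no measured pair shows this change, so its size is unknown from the series. The expectation in this assay is a small step toward a lower number, not clearly beyond the scatter. Compound 4 is estimated at 4000 nM, with a range from 1500 nM to 15000 nM. The expected step is a 1.6-fold lower number from compound 3 to compound 4 (0.20 log units; within the scatter).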

Compound 4, half-maximal inhibitory concentration: 11100 nM
For compound 4 the middle estimate is 2.8-fold (0.44 log units) below the measured one, within the range that was stated.
By their numbers in this assay, from the lowest: compounds 3, 4, 1 and 2 (each within the scatter of the next, the first and the last beyond it).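

In this assay, hydrogen in place of bromo gives a 1.7-fold higher number from compound 3 to compound 4 (0.24 log units; within the scatter) and so gives this aromatic carbon its first one-place reading, which does not separate the two groups. Methoxy in place of nitro on an aromatic carbon gives a 2.0-fold lower number from compound 2 to compound 4 (0.30 log units; within the scatter) and likewise does not separate them. Nothing available accounts for either step. From the compounds shown here alone, whether an amine or a carboxylic acid on the carbon carrying bromo in compound 3 would produce a step beyond the scatter remains open.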